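The source may report more compounds than this note shows. Statements on the series, on what has been measured and on what is new or still open speak of the compounds shown alone.

Measured in an ADME assay on KB cells (Homo sapiens) for cytotoxicity, read by MTT assay, with a stated time of 72 h; on this read-out higher numbers stand for lower toxicity in this test and lower numbers for higher toxicity in this test:
- compound 1 `Clc1ccc(Nc2nc(-c3ccccn3)c(Cl)s2)nc1` gives 326000 nM
- compound 2 `Clc1ccc(Nc2nc(-c3cccnn3)c(Cl)s2)nc1` gives 28100 nM
- compound 3 `Clc1ccc(Nc2nc(-c3ncccn3)cs2)nc1` gives 20700 nM

Compound 3 and compound 2 lie within the scatter of each other, and the number of compound 1 stands well above both. Compound 4 `Clc1ccc(Nc2nc(-c3ncccn3)c(Cl)s2)nc1` is compound 3 with a single change, chloro in place of hydrogen on an aromatic carbon. Going by the values given here, no measured step shows this change directly. Among the compounds with values here, the only measured step, a 12-fold lower number from compound 1 to compound 2 (1.06 log units; beyond the scatter), puts pyridazin-3-yl in place of pyridin-2-yl with the chloro kept, so among compounds carrying chloro the number in this assay can move widely with the attached ring. Of the two compounds carrying chloro in that place, compound 2 (28100 nM) reads within the scatter of compound 3, while compound 1 (326000 nM) reads far higher. A modest move towards a higher number, lower toxicity in this test, is therefore expected, with much uncertainty, and a step within the scatter would not surprise. The expected change is a 2.4-fold higher number from compound 3 to compound 4 (0.38 log units; beyond the scatter). For compound 4 the estimated value is 50000 nM, with an expected range from 15000 nM to 200000 nM.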

Compound 4, half-maximal cytotoxic concentration in the KB assay: 66100 nM
Compound 4: the middle estimate sits 1.3-fold (0.12 log units) below what was measured, within the range that was stated.
By their numbers in the KB assay, from the lowest: compounds 3 and 2 (each within the scatter of the next); then compound 4; then compound 1.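

Chloro in place of hydrogen on the aromatic carbon next to the ring sulfur can now be read directly, and in the KB assay it gives a 3.2-fold higher number from compound 3 to compound 4 (0.50 log units; beyond the scatter), a modest move towards lower toxicity in this test. With that chloro kept, the attached ring still moves the number in the KB assay: pyrimidin-2-yl gives a 2.4-fold higher number from compound 2 to compound 4 (0.37 log units; beyond the scatter) and a 4.9-fold lower number from compound 1 to compound 4 (0.69 log units; beyond the scatter), so the three compounds carrying chloro are spread out by the ring alone, with compound 4 lying between the other two. In a physicochemical assay for solubility, in phosphate buffer, with a stated time of 2 h, at pH 7.4 (a higher number here means a more soluble compound, a lower number a less soluble compound), compound 3 gives 20000 nM as a number. In the physicochemical assay compound 4 gives < 10000 nM as a limit of the assay and not as a number. In the physicochemical assay the same change gives an at least 2.0-fold lower number from compound 3 to compound 4 (0.30 log units; that floor lies within the scatter) and the true size of this step stays unknown: the limit of < 10000 nM in the physicochemical assay, at which 1 of the 2 values shown sits.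

The compounds shown leave open whether the change from hydrogen to chloro has a similar size with pyridin-2-yl or pyridazin-3-yl in place of pyrimidin-2-yl. They also leave open how a methyl group, a fluoro group or an amine on that same carbon would read in the KB assay.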